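The source may hold more compounds than are shown below. What is called first, only, known or untested is meant among the compounds shown, and "the series" means these compounds.

Measured in an assay on isolated protein for binding affinity to leukotriene B4 receptor 1 (Homo sapiens), tested at 1 uM; on this read-out higher numbers stand for more inhibition at the one concentration tested (going by the name of the read-out) and lower numbers for less inhibition:

Compound 1, `CCCCCc1cc(C(C)=O)c(O)cc1OCCCCC#N`, gives 14%.
Compound 2, `CSCc1cc(C(C)=O)c(O)cc1OCCCCCCC#N`, gives 64%.
Compound 3, `C=CCc1cc(C(C)=O)c(O)cc1OCCCC`, gives 8%.

Compound 3 sits at the low end of these three numbers. Its value and that of compound 1 fall within the usual scatter of each other, so nothing separates them. Compound 2, on the other hand, stands well beyond the scatter above compound 3. Compound 2 differs from compound 3 in more than one place, and these numbers alone do not show which of those places matters.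

Compound 4, `C=CCc1cc(C(C)=O)c(O)cc1OCCCCCC(C)=O`, shares the core of compound 3 and differs from it in a single way: 2-oxopropyl in place of hydrogen on a saturated chain carbon, four bonds along the chain from an oxygen on an aromatic ring. The chain on the aromatic oxygen is thereby lengthened and ends in a carbonyl.

Going by the values given here, no measured pair here isolates this change, so the expectation rests on the general picture that the longer, carbonyl-ended chain is expected to move the number upward by a modest step, a number 17 percentage points higher from compound 3 to compound 4 (beyond the scatter), perhaps just beyond the scatter. Compound 4 is therefore estimated at 25% in this assay, with a plausible range from 5% to 55%.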

Compound 4, a percentage reported as inhibition, at one concentration (the size of the read-out at that concentration, not a potency): 58%
Compound 4: the middle estimate sits 33 percentage points below what was measured; the whole stated range lies below it.
By their numbers in this assay, from the lowest: compounds 3 and 1 (each within the scatter of the next); then compounds 4 and 2 (each within the scatter of the next).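

In this assay, the chain on the aromatic oxygen proves to be a place where a single change can matter greatly. With 2-oxopropyl in place of hydrogen on a saturated chain carbon, four bonds along the chain from an oxygen on an aromatic ring, the result is a number 50 percentage points higher from compound 3 to compound 4 (beyond the scatter) and this step is large. The earlier compounds could not show this, as each of them differed from the others in more than one place, so none of their gaps could be tied to a single site; the new pair ties a large gain to this one site, but no measurement available here explains the gain.

The change both lengthens the chain and ends it in a carbonyl, so the compounds shown leave open which of the two carries the step. A plain hexyl or longer alkyl chain with no carbonyl would separate the two, and a hydroxyl group or a carboxylic acid at the chain end would show whether the ketone itself is needed.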